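The source may hold more compounds than are shown below. What is called first, only, known or untested is meant among the compounds shown, and "the series" means these compounds.

Measured compounds, growth inhibition on the prostate cell line:

compound 1, `CC(C)COC(=O)Nc1ccc([Se][Se]c2ccc(NC(=O)OCC(C)C)cc2)cc1` — 24200 nM
compound 2, `CCCCOC(=O)Nc1ccc([Se]C#N)cc1` — 12400 nM
compound 3, `CCCCOC(=O)Nc1ccc([Se][Se]c2ccc(NC(=O)OCCCC)cc2)cc1` — 28600 nM

In a functional assay on PC-3 cells (Homo sapiens) for cytotoxicity, read by MTT assay, with a stated time of 72 h (on this read-out lower numbers stand for stronger inhibition of growth and higher numbers for weaker inhibition of growth), compound 2 carries the lowest number of the three. Its gap to compound 1 lies within the usual scatter, so the two cannot be ranked against each other; its gap to compound 3 lies beyond the scatter. Compound 2 and compound 3 share the butyl carbamate, the one as a selenocyanate, the other as a diselenide.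

Compound 4, `N#C[Se]c1ccc(NC(=O)Oc2ccccc2)cc1`, keeps the selenocyanate of compound 2 and changes the carbamate ester: phenyl in place of butyl on an oxygen next to a carbonyl group. Within the data shown here, no pair of measured compounds shows this exchange, so its effect on this assay has to be estimated without precedent. Within the three measured compounds, a change of the carbamate alkyl group (compound 1 against compound 3) stays within the scatter, which gives no sign that the ester portion moves the number much. The step expected for compound 4, a 1.1-fold lower number from compound 2 to compound 4 (0.05 log units; within the scatter), is therefore set at none beyond the scatter. Compound 4 is estimated at 11000 nM, with a range from 4000 nM to 30000 nM.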

Compound 4, concentration for 50% growth inhibition: 9100 nM
Compound 4: middle estimate off by 1.2-fold (0.08 log units), on the high side; the range from low to high includes it.
By their numbers in this assay, from the lowest: compounds 4, 2, 1 and 3 (each within the scatter of the next, the first and the last beyond it).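

In this assay, the only direct test of this position gives a 1.4-fold lower number from compound 2 to compound 4 (0.13 log units; within the scatter), with the selenocyanate held fixed and phenyl in place of butyl on an oxygen next to a carbonyl group. The earlier compounds shown here carried only open chains at this place, whereas this step shows that one six-membered aromatic ring of carbon only can replace butyl with no change beyond the scatter, so this single exchange gives no sign that the number depends on the kind of group here. No measured property of these compounds bears on this result, and it remains an observation on one pair without an explanation.

The compounds shown leave open whether a group of a different kind on this oxygen, such as one carrying an amine or a carboxylic acid, or a longer chain such as octyl, would produce a step beyond the scatter. They also leave open whether the exchange of butyl for phenyl would give a similar step in a diselenide such as compound 3.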